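The source may report more compounds than this note shows. Statements on the series, on what has been measured and on what is new or still open speak of the compounds shown alone.

Compounds measured in a physicochemical assay for lipophilicity, read by LC-MS, in phosphate buffer, measured as octanol-water partition, with a stated time of 30 min, at pH 7.4, tested at 200 mM; on this read-out lower numbers stand for lower lipophilicity and higher numbers for higher lipophilicity:
compound 1 `Cc1ccc(Oc2ccc3nc(COc4cccc(C(=O)O)c4)n(C)c3n2)cc1F` gives 2.1
compound 2 `Cc1ccc(Oc2ccc3nc(COc4cccc(C(=O)O)c4)n(C)c3n2)cc1C` gives 2.2
compound 3 `Cn1c(COc2cccc(C(=O)O)c2)nc2cnc(Oc3ccc(Cl)c(F)c3)cc21` gives 1.4

Compound 3 stands lowest of the three numbers: compound 1 lies higher by a gap beyond the scatter, and compound 2 lies further still. Compound 4 `Cn1c(COc2cccc(C(=O)O)c2)nc2cnc(Oc3ccc4c(c3)OCC4)cc21` differs from compound 3 by a group of 9 heavy atoms (8 carbon, 1 oxygen; one five-membered non-aromatic ring with 1 hetero atom, one six-membered aromatic ring of carbon only) in place of a group of 8 heavy atoms (6 carbon, 1 fluorine, 1 chlorine; one six-membered aromatic ring of carbon only), on an oxygen on an aromatic ring. Among the compounds with values here, no measured step matches this change; the only step available, a number 0.10 log units higher from compound 1 to compound 2 (within the scatter), concerns an exchange of small substituents and tells little about removing both halogens and fusing a ring. The expectation therefore rests on the structural change alone: losing the chloro and fluoro groups is expected to lower this assay by about a number 0.80 log units lower from compound 3 to compound 4 (beyond the scatter). Compound 4 is estimated at 0.6, within a range of 0.1 to 1.1.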

Compound 4, distribution coefficient: 0.6
For compound 4 middle estimate and measured number coincide at the digits printed, and the stated range covers the measured number.
By their numbers in this assay, from the lowest: compound 4; then compound 3; then compounds 1 and 2 (each within the scatter of the next).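

In this assay, placing the group with a five-membered non-aromatic ring on the oxygen on an aromatic ring, where the 4-chloro-3-fluorophenyl group stood, gives a number 0.80 log units lower from compound 3 to compound 4 (beyond the scatter). The only earlier step, a number 0.10 log units higher from compound 1 to compound 2 (within the scatter), exchanged a single small substituent, so this is the first step shown in which replacing a whole group moves the number beyond the scatter. Nothing available accounts for the size of this step. The compounds shown leave open how much of the step belongs to the chloro, the fluoro or the fused ring, as all of them change at once. Going by these compounds, how a phenyl group carrying an amine or a methoxy group would read at this place also remains open.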